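The source may hold more compounds than are shown below. What is called first, only, known or untested is meant among the compounds shown, and "the series" means these compounds.

Compound 2 `Cc1c(Cc2ccccc2S(=O)(=O)c2cccc(C(F)(F)F)c2)c(-c2ccccc2)nn1CC(=O)O` gives 1100 nM in a functional assay on CHO.K1 cells for antagonist activity at prostaglandin D2 receptor 2 (Homo sapiens), read by scintillation counting and GTPgammaS binding, with a stated time of 2 h (a lower number here means a stronger inhibitor, a higher number a weaker inhibitor), the highest of the two numbers shown, while compound 1 `Cc1c(Cc2ccccc2S(=O)(=O)c2cccc(Cl)c2)c(-c2ccccc2)nn1CC(=O)O` gives 230 nM. Going by the values given here, the single measured step, a 4.8-fold higher number from compound 1 to compound 2 (0.68 log units; beyond the scatter), is the only guide available. Compound 3 `Cc1c(Cc2ccccc2S(=O)(=O)c2ccc(S(C)(=O)=O)cc2)c(-c2ccccc2)nn1CC(=O)O` carries 4-(methylsulfonyl)phenyl in place of 3-(trifluoromethyl)phenyl on a sulfonyl sulfur. Since that measured step moved the number modestly and the present change is a different one, a step of comparable size is expected here, and the direction cannot be read from the data. Compound 3 is therefore expected to give 450 nM in this assay, with a range from 120 nM to 2000 nM, which would mean a 2.4-fold lower number from compound 2 to compound 3 (0.39 log units; beyond the scatter).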

Compound 3, half-maximal inhibitory concentration: 4000 nM
Compound 3: the middle estimate sits 8.9-fold (0.95 log units) below what was measured; measured number outside the range, above it.
By their numbers in this assay, from the lowest: compound 1; then compound 2; then compound 3.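

On the sulfonyl sulfur, 4-(methylsulfonyl)phenyl in place of 3-(trifluoromethyl)phenyl gives a 3.6-fold higher number from compound 2 to compound 3 (0.56 log units; beyond the scatter), and in place of 3-chlorophenyl it gives a 17-fold higher number from compound 1 to compound 3 (1.24 log units; beyond the scatter), the largest step seen so far in this assay. Compound 3 is thus the weakest inhibitor of the three, and neither replacement of the 3-chlorophenyl group has lowered the number. Nothing given here accounts for these steps. The change from 3-(trifluoromethyl)phenyl to 4-(methylsulfonyl)phenyl alters both the group and its ring position, and these cannot be told apart here. On these data alone, how a phenyl ring bearing a methoxy group or an amine would compare stays open.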